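The source may hold more compounds than are shown below. What is called first, only, known or untested is meant among the compounds shown, and "the series" means these compounds.

Among the compounds with values here, in an ADME assay on J774.A1 cells (Mus musculus) for cytotoxicity, read by MTT assay, with a stated time of 48 h (on this read-out higher numbers stand for lower toxicity in this test and lower numbers for higher toxicity in this test), compound 1 (`COC(=O)c1c(NCCNc2ccnc3cc(Cl)ccc23)noc1-c1ccccc1[N+](=O)[O-]`) gives 73600 nM and is the only compound with a number. For compound 2 (`COC(=O)c1c(NCCCNc2ccnc3cc(Cl)ccc23)noc1-c1ccccc1[N+](=O)[O-]`) the entry reads "not determined" (no result reported) and offers no comparison. Compound 3 (`COC(=O)c1c(NCCNc2ccnc3cc(Cl)ccc23)noc1-c1ccc(Cl)cc1Cl`) is still unmeasured and differs from compound 1 at one place on the shared core. The change is 2,4-dichlorophenyl in place of 2-nitrophenyl on an aromatic carbon on an aromatic carbon next to the ring oxygen. Within the data shown here, no measured step bears on this change. In this assay no step beyond the scatter is expected, and the estimated 1.5-fold lower number from compound 1 to compound 3 (0.17 log units; within the scatter) leans slightly towards lower numbers. For compound 3 the expected value is 50000 nM within an estimated range from 17000 nM to 130000 nM in this test.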

Compound 3, half-maximal cytotoxic concentration: 3450 nM
Estimate against measurement, compound 3: 14-fold (1.16 log units) above; the measured number lies below the stated range.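

In this assay, the aromatic carbon next to the ring oxygen proves sensitive to the group it carries: 2,4-dichlorophenyl in place of 2-nitrophenyl gives a 21-fold lower number from compound 1 to compound 3 (1.33 log units; beyond the scatter), which points towards higher toxicity in this test. Within the data shown here, this is the first readable step at this position, and it shows that the change of aryl group alone can shift the read-out substantially. Nothing available explains the step.

The compounds shown leave open whether the shift follows the arrival of the two chlorines or the loss of the nitro group, as both change together. A plain phenyl or a 4-chlorophenyl group at this place would be needed to separate the two.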